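This account rests on a few compounds, and the source may have more. Where it says the series, first, only, none or still open, it means among the compounds named here.

Measured compounds:
- compound 1 `COC(=O)C(=O)CNC1=CS(=O)(=O)O[C@@]12[C@@H](CO[Si](C)(C)C(C)(C)C)O[C@@H](n1cc(C)c(=O)n(C)c1=O)[C@@H]2O[Si](C)(C)C(C)(C)C`: in a functional assay on MT4 cells (Homo sapiens) (a higher number here means that more compound is tolerated, a lower number that less compound is tolerated), compound 1 gives 10300 nM
- compound 2 `Cc1cn([C@@H]2O[C@@H]3COC4(O)CS(=O)(=O)O[C@@]34[C@H]2O[Si](C)(C)C(C)(C)C)c(=O)[nH]c1=O`: in this assay compound 2 gives 100000 nM

Compound 1 holds the lowest of the two numbers in this assay; compound 2 gives the higher number, and the gap between the two is beyond the scatter. Within the data shown here, no single-point step joins compound 1 and compound 2, the two structures differing in several places, so nothing more than the two values themselves can be read from that pair.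

Compound 3 `COC(=O)CC(=O)NC1=CS(=O)(=O)O[C@@]12[C@@H](CO[Si](C)(C)C(C)(C)C)O[C@@H](n1cc(C)c(=O)n(C)c1=O)[C@@H]2O[Si](C)(C)C(C)(C)C` is not yet measured in this assay. It differs from compound 1 in one place: ((methoxycarbonyl)methyl)carbonyl in place of ((methoxycarbonyl)carbonyl)methyl on an amine nitrogen. The two compounds share every atom and differ only in how the chain on the amine nitrogen is joined up. Among the measured compounds shown here, no measured step of this kind exists, so the size of the step can only be guessed. The expectation is for a step of a 1.2-fold higher number from compound 1 to compound 3 (0.07 log units; within the scatter) that stays within the scatter, with no clear direction. For compound 3 in this assay a value of 12000 nM is estimated, within a range of 4000 nM to 40000 nM.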

Compound 3, half-maximal cytotoxic concentration: 11900 nM
For compound 3 the middle estimate is 1.0-fold (0.00 log units) above the measured one; measured number inside the range.
By their numbers in this assay, from the lowest: compounds 1 and 3 (each within the scatter of the next); then compound 2.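

In this assay, among these compounds, ((methoxycarbonyl)methyl)carbonyl in place of ((methoxycarbonyl)carbonyl)methyl on the amine nitrogen gives a 1.2-fold higher number from compound 1 to compound 3 (0.06 log units; within the scatter), the first single-point step, and it lies within the scatter. The two chains have the same atoms joined in a different order, so at this position, on this core, that rearrangement produces no resolvable difference in the tolerated concentration, although this rests on a single pair. No independent measurement is available to account for this result.

As far as these compounds go, it remains open whether the position tolerates changes in the chain's make-up as well as in its connectivity: a carboxylic acid in place of the methyl ester, a terminal amine or a longer chain on the same nitrogen would each test that. The unsubstituted amine on the shared core would show whether the chain contributes to the values of compound 1 and compound 3 at all, and so whether the flat step reflects the chain or the rest of the molecule.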